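Swapping the ester chain for isobutyl in compound 4

This account rests on a few compounds, and the source may have more. Where it says the series, first, only, none or still open, it means among the compounds named here.

Measured in a functional assay on FaDu cells (Homo sapiens) for cytotoxicity, read by MTT assay, with a stated time of 72 h; a higher number here means that more compound is tolerated, a lower number that less compound is tolerated:
- compound 1 `CCOc1ccc(NC(=O)C(=O)c2cn(C(C)C)c3ccccc23)cn1`: 175 nM
- compound 2 `COC(=O)CCn1cc(C(=O)C(=O)Nc2ccc(OC)nc2)c2ccccc21`: 168 nM
- compound 3 `CC(C)n1cc(C(=O)C(=O)Nc2ccc(C(F)(F)F)nc2)c2ccccc21`: > 10000 nM, a limit of the assay

Compound 2 gives 168 nM and compound 1 gives 175 nM, two values within the scatter of each other. The only other result, for compound 3, is a limit and not a number.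

The next compound is compound 4 `COc1ccc(NC(=O)C(=O)c2cn(CC(C)C)c3ccccc23)cn1`. It differs from compound 2 by isopropyl in place of (methoxycarbonyl)methyl on a saturated chain carbon bound to an aromatic nitrogen. Cut one bond further out, this is 2-(methoxycarbonyl)ethyl to isobutyl.

Among the measured compounds shown here, the one measured step, an at least 57-fold higher number from compound 1 to compound 3 (1.75 log units; beyond the scatter), is large, but it is trifluoromethyl in place of ethoxy on an aromatic carbon, so it concerns another place and says little here. More relevant is compound 1, which also lacks the methoxycarbonyl group and gives 175 nM. Compound 1 differs from compound 2 in more than that chain, so this support is limited.

In this assay, the expected change is a 1.0-fold higher number from compound 2 to compound 4 (0.01 log units; within the scatter), which is estimated to stay within the scatter. For compound 4 the estimated value is 170 nM, with an expected range of 50 nM to 600 nM.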

Compound 4, concentration lethal to 50% of the cells: 317 nM
Estimate against measurement, compound 4: 1.9-fold (0.27 log units) below, and the stated range covers the measured number.
By their numbers in this assay, from the lowest: compounds 2, 1 and 4 (each within the scatter of the next). At a limit, above all of these: compound 3.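

In this assay, putting isobutyl in place of 2-(methoxycarbonyl)ethyl gives a 1.9-fold higher number from compound 2 to compound 4 (0.28 log units; within the scatter). Among the compounds shown here, this is the first direct reading at this position, and it shows that the ester chain can leave without a shift beyond the scatter. The (methoxycarbonyl)methyl that leaves carries 2 hydrogen-bond acceptors and the isopropyl that enters carries 0, so these acceptors are not required at this place for a value of this order, though nothing shown explains the result.

Going by these compounds, whether this place also accepts a carboxylic acid, an amine or a longer chain remains open. So does whether the same exchange would read alike with ethoxy or trifluoromethyl in place of the methoxy group that compound 2 and compound 4 share.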